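Moving the chlorine on the benzyl ring of compound 1

This account rests on a few compounds, and the source may have more. Where it says the series, first, only, none or still open, it means among the compounds named here.

Compound 1 `Nc1cccc(/C=C2\SC(=O)N(Cc3cccc(Cl)c3)C2=O)c1` stands at the highest number of the three compounds measured in a functional assay on HeLa cells (Homo sapiens) for cytotoxicity, read by cell counting, with a stated time of 4 days; a lower number here means a stronger inhibitor, a higher number a weaker inhibitor: in that assay compound 1 gives 250000 nM. Compound 2 `Nc1ccc(/C=C2\SC(=O)N(Cc3cccc(Cl)c3)C2=O)cc1` gives 24000 nM, and compound 3 `C=C(Br)C(=O)Nc1cccc(/C=C2\SC(=O)N(Cc3cccc(Cl)c3)C2=O)c1` gives 2500 nM. Both steps away from compound 1 are large: a 10-fold lower number from compound 1 to compound 2 (1.02 log units; beyond the scatter), and a 100-fold lower number from compound 1 to compound 3 (2.00 log units; beyond the scatter). Compound 4 `Nc1cccc(/C=C2\SC(=O)N(Cc3ccc(Cl)cc3)C2=O)c1` keeps the 3-aminophenyl of compound 1 untouched and changes only the other ring: 4-chlorophenyl in place of 3-chlorophenyl on a saturated chain carbon bound to an amide-type nitrogen in a ring. For the measured compounds named here, neither of the two measured steps bears on this place; each of them alters the aminophenyl side and leaves the 3-chlorophenyl as it is, so no measured step speaks directly to the present change. With nothing to point either way, the step is expected to be small, within the scatter: no change at the digits printed from compound 1 to compound 4 (within the scatter). Compound 4 is therefore estimated at 250000 nM in this assay, with a range from 70000 nM to 900000 nM.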

Compound 4, half-maximal inhibitory concentration: > 250000 nM
Compound 4 was reported as a limit; the forecaster's own chance of this, stated with the estimate: 25%; the middle value sits exactly at the limit.
By their numbers in this assay, from the lowest: compound 3; then compound 2; then compound 1.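

In this assay compound 4 is reported only as a limit, > 250000 nM, not as a number. The size of the step from compound 1 cannot be read, but 4-chlorophenyl in place of 3-chlorophenyl on this saturated chain carbon gives a number no lower from compound 1 to compound 4 (the limit leaves the size open) unlike the changes on the aminophenyl side that lead to compound 2 and compound 3. This first reading of the chlorophenyl side rests on a single limit: the limit of > 250000 nM in this assay, at which 1 of the 4 values shown sits.

On these data alone, how far the number of compound 4 lies past that limit stays open, as does whether 4-chlorophenyl would keep the lower numbers seen with the aminophenyl changes of compound 2 and compound 3. Also open, as far as these compounds go, is what a methoxy group or a carboxylic acid in place of the chlorine would do in this assay.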